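A few compounds are considered here, and "the series" means these few. Any claim that something is new, unique, unknown or untested is made for them only; others in the source may bear on it.

Compound 1 `COc1cc(/C=C2\CN(C)C/C(=C\c3ccc(Br)cc3)C2=O)cc(OC)c1` and compound 2 `COc1cc(/C=C2\CN(C)C/C(=C\c3ccc(Cl)cc3Cl)C2=O)cc(OC)c1` share one core and differ in a single place: 2,4-dichlorophenyl in place of 4-bromophenyl on a double-bonded chain carbon bound to a double-bonded ring carbon. In a functional assay on THP-1 cells (Homo sapiens) for cytotoxicity, read by MTT assay, with a stated time of 24 h (a higher number here means a weaker inhibitor, a lower number a stronger inhibitor), compound 1 gives 4270 nM, and compound 2 gives 6070 nM, so the step is a 1.4-fold higher number from compound 1 to compound 2 (0.15 log units; within the scatter). Compound 3 `CN1C/C(=C\c2ccc(Br)cc2)C(=O)/C(=C/c2ccc(C#N)cc2)C1` keeps the 4-bromophenyl of compound 1 on a different core; how the two cores differ is not broken down here. In this assay compound 3 gives 4400 nM, a number that sits within the scatter of both compound 1 and compound 2.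

Compound 4 `CN1C/C(=C\c2ccc(C#N)cc2)C(=O)/C(=C/c2ccc(Cl)cc2Cl)C1` has not yet been tested. It stands to compound 3 exactly as compound 2 stands to compound 1: the change is 2,4-dichlorophenyl in place of 4-bromophenyl on a double-bonded chain carbon bound to a double-bonded ring carbon, the same change at the same place. Among the measured compounds shown here, the only measured instance of that change, a 1.4-fold higher number from compound 1 to compound 2 (0.15 log units; within the scatter), stayed within the scatter, and on that basis compound 4 is expected to land close to compound 3 in this assay. The expected step is a 1.3-fold higher number from compound 3 to compound 4 (0.11 log units; within the scatter). Compound 4 is estimated at 5700 nM, with the likely range expected to run from 2500 nM to 13000 nM.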

Compound 4, half-maximal inhibitory concentration: 1910 nM
Beside the measured number, compound 4's estimate is 3.0-fold (0.47 log units) above it; measured number below the stated range.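

In this assay, putting 2,4-dichlorophenyl in place of 4-bromophenyl gives a 2.3-fold lower number from compound 3 to compound 4 (0.36 log units; beyond the scatter), a step beyond the scatter, whereas the same change on the core of compound 1 stayed within it. The change therefore does not carry over unaltered from one core to the other: the same change on two cores in this assay, a 1.4-fold higher number (0.15 log units; within the scatter) from compound 1 to compound 2 and a 2.3-fold lower number (0.36 log units; beyond the scatter) from compound 3 to compound 4, 3.3-fold (0.52 log units) apart, beyond the scatter of two such steps. Among the compounds shown here, this rests on a single pair for each core, so it shows only that the two steps differ in this assay, not why they differ or how the change would behave on any further core.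

Among the compounds shown, only 4-bromophenyl and 2,4-dichlorophenyl are compared at this place, so it remains open whether a 4-chlorophenyl would follow the 4-bromophenyl or the 2,4-dichlorophenyl on each core. From the compounds shown here alone, it also remains open whether a plain phenyl or a pyridine there would show the same dependence on the core.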